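Methyl in place of fluoro on the cyclopropyl amide

The source may hold more compounds than are shown below. What is called first, only, known or untested is meant among the compounds shown, and "the series" means these compounds.

The measured compounds and their values:
Compound 1, `CCC(=O)N1CC2CC(C1)N2`: in an assay on SH-EP1 cells for agonist activity at Neuronal acetylcholine receptor; alpha4/beta2 (Homo sapiens), read by FLIPR and calcium flux (a lower number here means a smaller maximal response, a higher number a larger maximal response), compound 1 gives 110%.
Compound 2, `O=C(C1CCCC1)N1CC2CC(C1)N2`: in this assay compound 2 gives 68%.
Compound 3, `O=C([C@@H]1C[C@@H]1F)N1CC2CC(C1)N2`: in this assay compound 3 gives 110%.

Compound 3 stands level with compound 1 at the digits shown, and the two together are the highest of the three numbers. Compound 2, which carries a cyclopentyl on the carbonyl carbon, lies well below both, beyond the scatter. Among the measured compounds shown here, the one step that joins two measured compounds, no change at the digits printed from compound 1 to compound 3 (within the scatter), shows that trading ethyl for 2-fluorocyclopropyl leaves the maximal response unchanged.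

Compound 4, `C[C@H]1C[C@H]1C(=O)N1CC2CC(C1)N2`, differs from compound 3 in one place: methyl in place of fluoro on a saturated ring carbon. For the measured compounds named here, no measured pair tests a methyl in place of a fluoro, so the bearing of the earlier step is indirect. That step was flat, and the only large drop in the set came with a much bigger ring, not with a small substituent on the cyclopropyl. A step of no size beyond the scatter is therefore expected, with a modest downward lean to cover the untested change: a number 8 percentage points lower from compound 3 to compound 4 (within the scatter). Compound 4 is estimated at 102%, within 78% to 122%.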

Compound 4, largest response reached (Emax), in percent of the reference or control that the assay uses: 93%
Compound 4: the middle estimate sits 9 percentage points above what was measured; the measured number falls inside the stated range.
By their numbers in this assay, from the lowest: compound 2; then compound 4; then compounds 1 and 3 (each within the scatter of the next).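

The fluoro on this saturated ring carbon of the cyclopropyl cannot be swapped freely: in this assay methyl in its place gives a number 17 percentage points lower from compound 3 to compound 4 (beyond the scatter) and thus a step the earlier compounds had not shown for a small substituent on the cyclopropyl. The same result appears against the plain ethyl amide, with a number 17 percentage points lower from compound 1 to compound 4 (beyond the scatter) where the 2-fluorocyclopropyl had matched ethyl, so in this series a cyclopropyl amide keeps the maximal response of the ethyl amide with one of these two groups but not with the other, even though the change is modest and swaps one heavy atom for one heavy atom with no hydrogen-bond donor, acceptor or charge entering or leaving. Nothing at hand accounts for the difference between the two groups.

Still open, on these data alone, is whether the loss belongs to methyl alone or would follow any group other than fluoro on this ring carbon, a question that a chloro, a hydroxyl or an amine at the same place would address. Also open, as far as these compounds go, is whether a longer chain such as ethyl there would lower the response further in this assay or leave it where methyl put it.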